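Swapping a saturated ring for an aromatic one on compound 1

The compounds below may be only part of what the source reports. "The series", "measured", "known", "first", "only" and "open" are said of these compounds alone.

Measured compounds:
- compound 1, `Nc1ccccc1NC(=O)c1ccc(CSC(=S)N2CCN(C3CCCCC3)CC2)cc1`: 76.1%
- compound 2, `Nc1ccccc1NC(=O)c1ccc(CSC(=S)N2CCc3cc([N+](=O)[O-])ccc32)cc1`: 43.6%
- compound 3, `CN(Cc1ccncc1)C(=S)SCc1ccc(C(=O)Nc2ccccc2N)cc1`: 72.7%

In a functional assay on HeLa cells (Homo sapiens) for antiproliferative activity, read by CCK-8 assay, with a stated time of 72 h, tested at 8 uM (a higher number here means a stronger effect of the compound at the concentration tested, a lower number a weaker effect), compound 1 gives the highest of the three numbers. Compound 3 sits within the scatter of compound 1, so no order between the two can be claimed. Compound 2 lies well below compound 1, a gap beyond the scatter.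

Compound 4, `Cc1ccc(N2CCN(C(=S)SCc3ccc(C(=O)Nc4ccccc4N)cc3)CC2)cc1`, has not been measured. It differs from compound 1 in one place: 4-methylphenyl in place of cyclohexyl on an amine nitrogen in a ring.

Going by the values given here, no measured pair shows this kind of change, so its effect is unknown. Compound 4 is expected to stay close to compound 1, with the step from a number 10.1 percentage points lower from compound 1 to compound 4 (beyond the scatter) expected to be small, if anything slightly downward, and likely within the scatter. The estimate for compound 4 is 66%, in the range 45% to 84%.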

Compound 4, a percentage reported as inhibition, at one concentration (the size of the read-out at that concentration, not a potency): 24%
Compound 4: middle estimate off by 42 percentage points, on the high side, and the stated range ends above it.
By their numbers in this assay, from the lowest: compound 4; then compound 2; then compounds 3 and 1 (each within the scatter of the next).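

In this assay, the group on this ring nitrogen clearly matters: putting 4-methylphenyl in place of cyclohexyl gives a number 52.1 percentage points lower from compound 1 to compound 4 (beyond the scatter). Both groups are uncharged carbon rings without hydrogen-bond donors or acceptors, yet this one change makes a large difference. No available evidence explains the drop.

This single step cannot separate the effect of the aromatic ring from that of its methyl group. A plain phenyl on the same nitrogen would help tell these two apart.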